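This account rests on a few compounds, and the source may have more. Where it says the series, first, only, none or still open, it means among the compounds named here.

Compounds measured in an assay (Rattus norvegicus) for inhibition of Fatty-acid amide hydrolase 1 (Homo sapiens); a higher number here means a weaker inhibitor, a lower number a stronger inhibitor:
compound 1, `O=C(CCCCCCc1ccccc1)c1ncc(-c2cccc(C(=O)C(F)(F)F)c2)o1`, 16 nM
compound 2, `O=C(CCCCCCc1ccccc1)c1ncc(-c2ccc([N+](=O)[O-])cc2)o1`, 50 nM
compound 3, `O=C(CCCCCCc1ccccc1)c1ncc(-c2cc(C(F)(F)F)ccn2)o1`, 3.5 nM

Compound 2 gives the highest number of the three in this assay. Its nearest neighbour is compound 1, whose number is lower by an amount beyond the scatter; compound 3 stands furthest from it, again beyond the scatter. Among the compounds with values here, no two measured compounds differ in only one place, so no single step is known.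

Compound 4 is `NS(=O)(=O)c1ccc(-c2cnc(C(=O)CCCCCCc3ccccc3)o2)s1`. Within the data shown here, it differs from compound 2 thus: 5-sulfamoylthiophen-2-yl in place of 4-nitrophenyl on an aromatic carbon The other measured compounds carry different groups on the aromatic carbon of the shared core and give lower numbers than compound 2, but no direct step supports carrying that over. The step from compound 2 to compound 4 is expected to be small, a 1.7-fold lower number from compound 2 to compound 4 (0.22 log units; within the scatter), possibly within the scatter. Compound 4 is estimated at 30 nM, range 8 nM to 120 nM.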

Compound 4, inhibition constant: 3 nM
Estimate against measurement, compound 4: 10-fold (1.00 log units) above, and the stated range ends above it.
By their numbers in this assay, from the lowest: compounds 4 and 3 (each within the scatter of the next); then compound 1; then compound 2.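

In this assay, 5-sulfamoylthiophen-2-yl in place of 4-nitrophenyl gives a 17-fold lower number from compound 2 to compound 4 (1.22 log units; beyond the scatter), the first single-place step known at this aromatic carbon of the shared core. The number at this position therefore responds strongly to the group carried there, and the change goes well beyond the scatter. No measurement at hand accounts for the size of the step.

Going by these compounds, the change replaces the ring and its substituent together, so their separate contributions remain open. A 4-sulfamoylphenyl group and an unsubstituted thiophen-2-yl group at this position would separate them.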